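The source may report more compounds than this note shows. Statements on the series, on what has been measured and on what is new or still open speak of the compounds shown alone.

Results so far in an ADME assay on J744 cells (Mus musculus) for cytotoxicity, read by MTT assay, with a stated time of 48 h; a higher number here means a weaker inhibitor, a lower number a stronger inhibitor:

- Compound 1 `Cc1c(C(=O)N/N=C/c2ccco2)no[n+]1[O-]`: > 400000 nM, a limit of the assay and not a number.
- Compound 2 `Cc1c(C(=O)N/N=C/c2ccc(C(=O)O)cc2)no[n+]1[O-]`: > 400000 nM, a limit of the assay and not a number.
- Compound 3 `Cc1nc2ccccn2c1C(=O)N/N=C/c1c(-c2ccccc2)no[n+]1[O-]`: 56000 nM

Compound 2 has no exact value and stands at the limit of > 400000 nM in this assay, at which 2 of the 3 values shown sit. Its true position is therefore unknown, and it can only be read as a limit. Compound 3 gives a real number, 56000 nM, but its structure differs from compound 2 in more than one place, so it offers only loose guidance.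

Compound 4 `Cc1c(C(=O)N/N=C/c2ccc(C(F)(F)F)cc2)no[n+]1[O-]` is the next compound to be tested. It carries trifluoromethyl in place of carboxy on an aromatic carbon, para to a large group: trifluoromethyl in place of carboxy on an aromatic carbon. Among the measured compounds shown here, no measured pair shows what this swap does, so only a small shift towards stronger inhibition is expected, within the usual scatter. The expected change is an at least 1.4-fold lower number from compound 2 to compound 4 (0.15 log units; that floor lies within the scatter). The assay may well report only a limit again. For compound 4 the estimated value is 280000 nM, with an expected range from 80000 nM to 400000 nM.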

Compound 4, half-maximal inhibitory concentration: > 400000 nM
Compound 4 gave a limit, no number; the forecaster's own chance of this, stated with the estimate: 55%; middle value at least 1.4-fold (0.15 log units) away from the limit.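

Compound 2 and compound 4 both stand at a limit and not at a number, so trifluoromethyl in place of carboxy gives no readable step between them: the limit of > 400000 nM in this assay, at which 3 of the 4 values shown sit.

The compounds shown leave open whether this swap changes the true value at all, and in which direction.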